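This account rests on a few compounds, and the source may have more. Where it says the series, first, only, none or still open, it means among the compounds named here.

Measured in a functional assay on RAW264.7 cells (Mus musculus) for inhibition, read by Griess assay, with stated times of 2 h and 24 h; a higher number here means a weaker inhibitor, a lower number a stronger inhibitor:
compound 1 `COc1ccc([C@@H]2C/C(=N\O)c3c(O)cc(OCc4cn(Cc5ccccc5F)nn4)cc3O2)cc1O` gives 5710 nM
compound 2 `COc1ccc([C@@H]2CC(=O)c3c(O)cc(OCc4cn(Cc5ccccc5F)nn4)cc3O2)cc1O` gives 7320 nM
compound 3 `COc1ccc([C@@H]2CC(=O)c3c(O)cc(OCc4cn(Cc5cccc(C#N)c5)nn4)cc3O2)cc1O` gives 18000 nM

Compound 3 holds the highest number of the three; the nearest is compound 2 and the furthest compound 1, and both gaps are beyond the scatter, so compound 3 is the weakest inhibitor measured so far in this assay. Within the data shown here, the only single-point step among the measured compounds is a 2.5-fold higher number from compound 2 to compound 3 (0.39 log units; beyond the scatter), a modest change brought by exchanging the aromatic group on the benzyl carbon.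

Compound 4 `COc1ccc([C@@H]2CC(=O)c3c(O)cc(OCc4cn(C5CCC5)nn4)cc3O2)cc1O` is still to be measured. Its difference from compound 3 is cyclobutyl in place of 3-cyanobenzyl on an aromatic nitrogen. The 3-cyanobenzyl group, with its aromatic ring and nitrile, goes out and a cyclobutyl group, a small non-aromatic ring, comes in on the aromatic nitrogen of the five-membered ring with three nitrogens. Among the measured compounds shown here, the only step that bears on this position is a 2.5-fold higher number from compound 2 to compound 3 (0.39 log units; beyond the scatter), which shows that varying the group there shifts the number modestly. For the measured compounds named here, no measured compound carries a non-benzyl group at this position, so the direction is open. For compound 4 the expected step is a 1.3-fold lower number from compound 3 to compound 4 (0.11 log units; within the scatter), within the scatter. Compound 4 is estimated at 14000 nM, with a range of 5000 nM to 40000 nM.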

Compound 4, half-maximal inhibitory concentration: 15300 nM
Compound 4: middle estimate off by 1.1-fold (0.04 log units), on the low side; the range from low to high includes it.
By their numbers in this assay, from the lowest: compounds 1 and 2 (each within the scatter of the next); then compounds 4 and 3 (each within the scatter of the next).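

In this assay, among these compounds, cyclobutyl, the first non-benzyl group on this aromatic nitrogen, gives a 1.2-fold lower number from compound 3 to compound 4 (0.07 log units; within the scatter), so in this pair the loss of the six-membered aromatic ring and the nitrile leaves the number within the scatter. Set against the 2-fluorobenzyl group, the same cyclobutyl gives a 2.1-fold higher number from compound 2 to compound 4 (0.32 log units; beyond the scatter), and a 2.5-fold higher number from compound 2 to compound 3 (0.39 log units; beyond the scatter) is likewise beyond the scatter, so of the three groups shown at this position, only 2-fluorobenzyl goes with the lower number, while 3-cyanobenzyl and cyclobutyl cannot be told apart. Nothing available gives a reason for this pattern.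

As far as these compounds go, it remains open whether the fluorine carries the difference or the plain benzyl group would sit with compound 2, and whether moving the fluorine to another ring position would keep the lower number. A chain ending in an amine or a carboxylic acid on this nitrogen, or a larger saturated ring such as cyclohexyl, would show whether the number can go below that of compound 2 7320 nM at this position.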